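A few compounds are considered here, and "the series" means these few. Any claim that something is new, unique, unknown or untested is made for them only; others in the source may bear on it.

Compound 1 `COc1cc(/C=C/C(=O)Nc2ccccc2)ccc1OCCCCCCN1CCCCC1` gives 1.77 in a physicochemical assay for lipophilicity, using the shake flask method, measured as octanol-water partition, at pH 7.4; a lower number here means a more polar compound, a higher number a more lipophilic compound.
Compound 2 `COc1cc(/C=C/C(=O)Nc2ccccc2)ccc1OCCCCCCCCN(C)C` gives 1.74 in this assay.

Compound 2 has the lowest of the two numbers, and compound 1 lies within the scatter of it. The change to compound 3 `COc1cc(/C=C/C(=O)Nc2ccccc2)ccc1OCCCCCCCCCCN(C)C` is 2-(dimethylamino)ethyl in place of dimethylamino on a saturated chain carbon, eight bonds along the chain from an oxygen on an aromatic ring. For the measured compounds named here, only one measured step exists, and it is of a different kind: a number 0.03 log units lower from compound 1 to compound 2 (within the scatter) exchanged one group for another of similar size, while the new change lengthens the chain. Going by the values given here, that step therefore gives no direct precedent and the expectation rests on an untested extension. The chain grows by two carbons, and a step upward in this assay is expected, a number 0.66 log units higher from compound 2 to compound 3 (beyond the scatter), but with wide uncertainty. Compound 3 is thus estimated at 2.4, with a range from 1.7 to 3.1.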

Compound 3, partition coefficient: 1.8
For compound 3 the middle estimate is 0.60 log units above the measured one; low and high end bracket the measured number.
By their numbers in this assay, from the lowest: compounds 2, 1 and 3 (each within the scatter of the next).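

In this assay, putting 2-(dimethylamino)ethyl in place of dimethylamino, eight bonds along the chain from an oxygen on an aromatic ring, gives a number 0.06 log units higher from compound 2 to compound 3 (within the scatter), so the longer chain ending in the same amine cannot be told apart from the shorter one. Placing 4-(dimethylamino)butyl in place of piperidin-1-yl gives a number 0.03 log units higher from compound 1 to compound 3 (within the scatter), so all three compounds lie within the scatter of one another, across the chains and end groups shown. Nothing measured here offers an explanation for this result.

Going by these compounds, whether the numbers stay this close with a much shorter chain or a still longer one remains open. So does the outcome with a different end group on the chain, such as a morpholine ring or a carboxylic acid.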